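This account rests on a few compounds, and the source may have more. Where it says the series, first, only, none or still open, it means among the compounds named here.

Measured compounds:
Compound 1 `CS/C(=N\C(=O)c1ccno1)NC(=O)c1ccno1`. In a functional assay on HepG2 cells (Homo sapiens) for cytotoxicity, read by MTT assay, with a stated time of 72 h (a higher number here means that more compound is tolerated, a lower number that less compound is tolerated), compound 1 gives > 100000 nM, which is a limit of the assay.
Compound 2 `C[Se]/C(=N\C(=O)c1ccno1)NC(=O)c1ccno1`. In this assay compound 2 gives > 100000 nM, which is a limit of the assay.
Compound 3 `CS/C(=N\C(=O)c1cc(-c2ccccc2)nc2ccccc12)NC(=O)c1cc(-c2ccccc2)nc2ccccc12`. In this assay compound 3 gives > 100000 nM, which is a limit of the assay.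

From compound 1 to compound 2 the change is a group of 2 heavy atoms (1 carbon, 1 selenium; no ring) in place of a group of 2 heavy atoms (1 carbon, 1 sulfur; no ring), on a carbon with a double bond to nitrogen. The step is a step that the two limits leave unreadable from compound 1 to compound 2, since both sit at the limit of > 100000 nM in this assay, at which 3 of the 3 values shown sit.

Compound 4 `C[Se]/C(=N\C(=O)c1cc(-c2ccccc2)nc2ccccc12)NC(=O)c1cc(-c2ccccc2)nc2ccccc12` carries the same change on the core of compound 3: a group of 2 heavy atoms (1 carbon, 1 selenium; no ring) in place of a group of 2 heavy atoms (1 carbon, 1 sulfur; no ring), on a carbon with a double bond to nitrogen. The place is the same word for word in both pairs. The difference between the two cores is not broken down here.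

For compound 4 the expected step is a step that the limit leaves unreadable from compound 3 to compound 4, resting on the limit of > 100000 nM in this assay, at which 3 of the 3 values shown sit, and on the fact that compound 3 gives only a limit. Compound 4 is therefore estimated at 150000 nM, most likely again reported as a limit.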

Compound 4, concentration lethal to 50% of the cells: 65400 nM
Beside the measured number, compound 4's estimate is 2.3-fold (0.36 log units) above it; low and high end bracket the measured number.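

On the core of compound 3, the selenium-bearing group in place of methylsulfanyl gives an at least 1.5-fold lower number from compound 3 to compound 4 (0.18 log units; that floor lies within the scatter) in this assay. Going by these compounds, compound 3 gives only a limit, so the full size of this step stays unknown, and the same change on the core of compound 1 cannot be read, so nothing shows that the step carries from one core to the other. Compound 4 is the only compound shown with a number rather than a limit: the limit of > 100000 nM in this assay, at which 3 of the 4 values shown sit.

Open, on these data alone, is whether the change reads the same on a third core. Also open, as far as these compounds go, is how the selenium-bearing compounds respond when the methyl on selenium gives way to a longer chain, or when an amine or a carboxylic acid is added to the shared core.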